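From 3-methylphenyl to pyridin-2-yl in a cytotoxic series

This account rests on a few compounds, and the source may have more. Where it says the series, first, only, none or still open, it means among the compounds named here.

In a functional assay on DU-145 cells (Homo sapiens) for cytotoxicity, read by ELISA, with a stated time of 4 days (a lower number here means a stronger inhibitor, a higher number a weaker inhibitor), compound 1 `Cc1ccsc1-c1cc(-c2ccco2)cc(-c2ccccc2Cl)n1` gives 29900 nM while compound 2 `Cc1ccsc1-c1cc(-c2ccoc2)cc(-c2ccc(Cl)cc2)n1` gives 20100 nM and compound 3 `Cc1cccc(-c2cc(-c3ccoc3)cc(-c3ccc(Cl)s3)n2)c1` gives 20300 nM as its reading. Compound 3 lies within the usual scatter of both other compounds, so the three numbers cannot be ranked.

Compound 4 `Clc1ccc(-c2cc(-c3ccoc3)cc(-c3ccccn3)n2)s1` has not yet been measured. It carries pyridin-2-yl in place of 3-methylphenyl on an aromatic carbon. The site is next to the ring nitrogen and meta to both the 5-chlorothiophen-2-yl group and the furan-3-yl group.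

Going by the values given here, no measured pair of compounds differs in only one place, so the data offer no direct precedent for this change. Among the compounds with values here, the only guide is the narrow spread of values among compounds that differ in more than one place, with compound 1 at 29900 nM and compound 3 at 20300 nM still within the scatter of each other. The expected step of a 1.0-fold lower number from compound 3 to compound 4 (0.01 log units; within the scatter) is estimated to stay within the scatter in this assay with neither direction favoured. For compound 4 the estimated value is 20000 nM with an expected range from 8000 nM to 50000 nM around it.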

Compound 4, half-maximal inhibitory concentration: 20500 nM
Beside the measured number, compound 4's estimate is 1.0-fold (0.01 log units) below it, and the stated range covers the measured number.
By their numbers in this assay, from the lowest: compounds 2, 3, 4 and 1 (each within the scatter of the next).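

In this assay, going by these compounds alone, pyridin-2-yl in place of 3-methylphenyl gives a 1.0-fold higher number from compound 3 to compound 4 (0.00 log units; within the scatter), and this is the first comparison in which only one place differs. At this site, on an aromatic carbon next to the ring nitrogen, a six-membered aromatic ring of carbon only and one with 1 hetero atom therefore cannot be told apart by this read-out, even though only pyridin-2-yl carries a hydrogen-bond acceptor. No measurement is available that would account for this result.

The compounds shown leave open whether an amine, a carboxylic acid or a longer chain on this carbon would also read like the two aromatic rings, and whether the same exchange would read alike if the 5-chlorothiophen-2-yl or furan-3-yl group were replaced. Within the data shown here, they also leave open whether any change at this place can move the reading beyond the scatter, as the only step available so far stays within it.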